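The compounds below may be only part of what the source reports. "The series", "measured", "known", "first", "only" and "open" are said of these compounds alone.

Compounds 1, 2 and 3 share one core. Compound 1, `Oc1cccc(-c2cc(-c3ccccc3O)nc(-c3ccccc3O)c2)c1`, gives 5020 nM in a functional assay on HCT-15 cells (Homo sapiens) for cytotoxicity, read by CCK-8 assay, with a stated time of 4 days; on this read-out lower numbers stand for stronger inhibition and higher numbers for weaker inhibition. Compound 2, `Oc1ccc(-c2cc(-c3cccc(O)c3)cc(-c3cccc(O)c3)n2)cc1`, gives 3090 nM. Compound 3, `Oc1ccc(-c2cc(-c3cccc(O)c3)cc(-c3ccc(O)cc3)n2)cc1`, reaches only the limit of the assay at > 50000 nM, a limit and not a number; it is the weakest of the three measured. The measured step of an at least 16-fold higher number from compound 2 to compound 3 (1.20 log units; beyond the scatter) shows how sharply this assay responds to the position of one hydroxyl, with compound 3 sitting at the limit of > 50000 nM in this assay, at which 1 of the 3 values shown sits. Compound 4, `Oc1ccc(-c2cc(-c3cccc(O)c3)cc(-c3ccccc3O)n2)cc1`, differs from compound 3 by 2-hydroxyphenyl in place of 4-hydroxyphenyl on an aromatic carbon. Among the measured compounds shown here, no measured step tests this exact change, but compound 1 shows that 2-hydroxyphenyl groups are tolerated at 5020 nM, so the estimate is a gain an at least 6.2-fold lower number from compound 3 to compound 4 (0.79 log units; beyond the scatter), with compound 4 expected near 8000 nM, between 2500 nM and 40000 nM.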

Compound 4, half-maximal inhibitory concentration: > 50000 nM
Compound 4 gave a limit, no number (the forecaster's own chance of this, stated with the estimate: 20%); middle value at least 6.2-fold (0.79 log units) from the limit.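

With 2-hydroxyphenyl in place of 3-hydroxyphenyl at this position next to the ring nitrogen, this assay shows an at least 16-fold higher number from compound 2 to compound 4 (1.20 log units; beyond the scatter), so this swap costs activity just as 4-hydroxyphenyl did. The 2-hydroxyphenyl tolerated in compound 1 does not rescue this compound, with an at least 9.9-fold higher number from compound 1 to compound 4 (0.99 log units; beyond the scatter). The value of compound 4 is a limit, like that of compound 3, so the step between them cannot be read: the limit of > 50000 nM in this assay, at which 2 of the 4 values shown sit.

The compounds shown leave open how compound 3 and compound 4 rank against each other. They also leave open whether a methoxy group or an amine in place of the hydroxyl at this position would restore a measurable value.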